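Dimethoxyphenyl hydrazones in the paw edema assay

This account rests on a few compounds, and the source may have more. Where it says the series, first, only, none or still open, it means among the compounds named here.

Measured compounds:
compound 1 `O=C(N/N=C/c1ccccc1)c1cccnc1Nc1cccc(C(F)(F)F)c1`: 31%
compound 2 `O=C(N/N=C/c1ccc(F)cc1)c1cccnc1Nc1cccc(C(F)(F)F)c1`: 36.5%
compound 3 `COc1ccc(/C=N/NC(=O)c2cccnc2Nc2cccc(C(F)(F)F)c2)c(OC)c1`: 19.8%

In a functional assay on the whole organism (strain Wistar) for inhibition, with Rattus norvegicus as the target, read by paw edema, with a stated time of 4 h, at a dose of 10 mg/kg by the intraperitoneal route (on this read-out lower numbers stand for less inhibition and higher numbers for more inhibition at the one dose given (going by the name of the read-out)), compound 2 gives 36.5%, the highest of the three numbers; compound 1 lies a number 5.5 percentage points higher from compound 1 to compound 2 (within the scatter) from it, within the scatter, while compound 3 lies beyond it. The change to compound 4 `COc1ccc(/C=N/NC(=O)c2cccnc2Nc2cccc(C(F)(F)F)c2)cc1OC` is 3,4-dimethoxyphenyl in place of 4-fluorophenyl on a carbon with a double bond to nitrogen. The step that bears on it is a number 16.7 percentage points lower from compound 2 to compound 3 (beyond the scatter), where a dimethoxyphenyl also replaced the 4-fluorophenyl, and a number 11.2 percentage points lower from compound 1 to compound 3 (beyond the scatter) points the same way. A modest fall in this assay is therefore expected. Compound 4 is estimated at 24%, between 13% and 35%, an expected step of a number 12.5 percentage points lower from compound 2 to compound 4 (beyond the scatter).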

Compound 4, a percentage reported as inhibition, in the whole organism at one dose (the size of the read-out at that dose, not a potency): 52.9%
Estimate against measurement, compound 4: 28.9 percentage points below; measured number outside the range, above it.
By their numbers in this assay, from the lowest: compound 3; then compounds 1 and 2 (each within the scatter of the next); then compound 4.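

At this carbon with a double bond to nitrogen, a dimethoxyphenyl group does not by itself lower the number in this assay: moving from 2,4-dimethoxyphenyl to 3,4-dimethoxyphenyl gives a number 33.1 percentage points higher from compound 3 to compound 4 (beyond the scatter), so the arrangement of the two methoxy groups decides the direction of the change. The 3,4-dimethoxyphenyl group also improves on both 4-fluorophenyl, with a number 16.4 percentage points higher from compound 2 to compound 4 (beyond the scatter), and phenyl, with a number 21.9 percentage points higher from compound 1 to compound 4 (beyond the scatter). Nothing measured here explains these differences. Going by these compounds, whether a single methoxy group or a hydroxy group on this ring would give a similar number remains open. So does whether this order holds at other doses.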